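Chromone sulfonamides: adding a pyrimidine ring to compound 3

A few compounds are considered here, and "the series" means these few. Any claim that something is new, unique, unknown or untested is made for them only; others in the source may bear on it.

Measured compounds:
compound 1 `Cc1cc(C)nc(NS(=O)(=O)c2ccc(N3C(=O)/C(=C/c4coc5ccccc5c4=O)N=C3c3ccc(Cl)cc3)cc2)n1` — 93900 nM
compound 2 `O=C1/C(=C/c2coc3ccccc3c2=O)N=C(c2ccccc2)N1c1ccc(S(=O)(=O)Nc2ncccn2)cc1` — limit, > 100000 nM
compound 3 `CCOC1Oc2ccccc2C(=O)/C1=C/Nc1ccc(S(N)(=O)=O)cc1` — 22200 nM

In a functional assay on MCF7 cells (Homo sapiens) for cytotoxicity, read by sulforhodamine B assay, with a stated time of 72 h (on this read-out lower numbers stand for stronger inhibition and higher numbers for weaker inhibition), compound 3 gives the lowest of the two numbers shown, with compound 1 at 93900 nM as the nearest neighbour, a gap beyond the scatter. Compound 2 reaches only a limit of this assay, (the limit of > 100000 nM in this assay, at which 1 of the 3 values shown sits). Compound 4 `CCOC1Oc2ccccc2C(=O)/C1=C/Nc1ccc(S(=O)(=O)Nc2ncccn2)cc1` is not yet measured; it keeps the core of compound 3 and carries pyrimidin-2-yl in place of hydrogen on a sulfonamide nitrogen. Among the compounds with values here, no measured pair separates this change by itself, so its size is open. A small step from compound 3 to compound 4 is expected, a 1.6-fold higher number from compound 3 to compound 4 (0.20 log units; within the scatter), toward a weaker or unchanged result. Compound 4 is estimated at 35000 nM, with a plausible range from 10000 nM to 100000 nM.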

Compound 4, half-maximal inhibitory concentration: 30100 nM
Compound 4: the middle estimate sits 1.2-fold (0.07 log units) above what was measured, and the stated range covers the measured number.
By their numbers in this assay, from the lowest: compounds 3 and 4 (each within the scatter of the next); then compound 1. At a limit, above all of these: compound 2.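

In this assay, pyrimidin-2-yl in place of hydrogen on a sulfonamide nitrogen gives a 1.4-fold higher number from compound 3 to compound 4 (0.13 log units; within the scatter), so this added ring does not measurably shift the result. Within the data shown here, the earlier compounds offered no pair differing only here, making this the first direct reading of the change. Nothing measured here explains this outcome.

As far as these compounds go, it remains open whether this nitrogen would accept other groups, such as an acetyl group or a chain ending in a carboxylic acid, equally well. From the compounds shown here alone, whether any group here could give a clearly lower number also remains open.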